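Cytotoxicity notes: benzoyl in place of isobutylsulfanyl

The source may report more compounds than this note shows. Statements on the series, on what has been measured and on what is new or still open speak of the compounds shown alone.

Measured so far:
compound 1 `CCC(CC)O[C@@H]1C=C(C(=O)O)C[C@H](NCc2ccc(SCC(C)C)cc2)[C@H]1NC(C)=O` — > 200000 nM
compound 2 `CCC(CC)O[C@@H]1C=C(C(=O)O)C[C@H](NCc2cccc(-c3ccc(SC)cc3)c2)[C@H]1NC(C)=O` — > 200000 nM

In an ADME assay on cells (Fibroblast, Gallus gallus) for cytotoxicity, read by CCK-8 assay, with a stated time of 48 h (on this read-out lower numbers stand for higher toxicity in this test and higher numbers for lower toxicity in this test), compound 1 returns only a limit, > 200000 nM. Compound 2 likewise returns only a limit in this assay, > 200000 nM. Compound 1 thus stands at the upper edge of what this assay reports; its value is not a number, and the other value shown is a limit as well, so no ordering between compound 1 and compound 2 can be drawn from these two entries. The position is summed up by the limit of > 200000 nM in this assay, at which 2 of the 2 values shown sit.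

The next compound is compound 3 `CCC(CC)O[C@@H]1C=C(C(=O)O)C[C@H](NCc2ccc(C(=O)c3ccccc3)cc2)[C@H]1NC(C)=O`. It differs from compound 1 by benzoyl in place of isobutylsulfanyl on an aromatic carbon. Among the measured compounds shown here, no step between measured compounds is available to calibrate this change, so the expectation rests on the two limits alone. With both measured values sitting at the limit, no shift beyond the scatter is expected for compound 3 in this assay, and the step of a number no higher from compound 1 to compound 3 (the limit leaves the size open) is estimated accordingly. Compound 3 is expected to give about 200000 nM in this assay, with a range from 100000 nM to 400000 nM, most probably reported again as a limit rather than a number.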

Compound 3, half-maximal cytotoxic concentration: > 200000 nM
Compound 3: no number, only a limit; the forecaster's own chance of this, stated with the estimate: 80%; the middle value sits exactly at the limit.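

Among the compounds shown here, compound 3 returns only a limit in this assay, > 200000 nM; compound 1 also gives only a limit there, so no step between compound 1 and compound 3 can be read. The compounds shown leave open whether any change on this shared core yields a number rather than a limit, the position being: the limit of > 200000 nM in this assay, at which 3 of the 3 values shown sit.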